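The source may hold more compounds than are shown below. What is called first, only, known or untested is meant among the compounds shown, and "the series" means these compounds.

Compound 2, `CNc1c(C#N)[n+]([O-])c2cc(Cl)ccc2[n+]1[O-]`, stands highest of the two numbers recorded in a functional assay on Ehrlich cells (Mus musculus) for cytotoxicity, read by trypan blue exclusion, with a stated time of 2 h, tested at 100 ug/mL; a higher number here means a weaker effect of the compound at the concentration tested, a lower number a stronger effect; compound 2 gives 72%. Its nearest neighbour is compound 1, `N#Cc1c(N)[n+]([O-])c2ccc(Cl)cc2[n+]1[O-]`, which in this assay gives 5%. Among the measured compounds shown here, the only step measured so far, a number 67 percentage points higher from compound 1 to compound 2 (beyond the scatter), is large and beyond the scatter.

Compound 3, `CC(=O)N(C(C)=O)c1c(C#N)[n+]([O-])c2cc(Cl)ccc2[n+]1[O-]`, differs from compound 2 by diacetylamino in place of methylamino on an aromatic carbon: methylamino leaves and diacetylamino enters, on an aromatic carbon of a six-membered aromatic ring with 2 nitrogen, next to the ring nitrogen and ortho to a cyano group. For the measured compounds named here, no measured step covers this exact change. The step of a number 67 percentage points higher from compound 1 to compound 2 (beyond the scatter) bears on it only loosely, since it too replaces a hydrogen on that nitrogen, and it was large and upward in number. That gives no firm size or direction for the present change, so the expectation for compound 3 is a step of a number 3 percentage points higher from compound 2 to compound 3 (within the scatter) in this assay, which is within the scatter, with a wide range on either side. Compound 3 is therefore estimated at 75% in this assay, expected between 35% and 100%.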

Compound 3, a percentage reported as activity, at one concentration (the size of the read-out at that concentration, not a potency): 0%
Compound 3: middle estimate off by 75 percentage points, on the high side; measured number below the stated range.
By their numbers in this assay, from the lowest: compounds 3 and 1 (each within the scatter of the next); then compound 2.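

At this position, on the aromatic carbon next to the ring nitrogen and ortho to a cyano group, substitution on the nitrogen does not push the read-out of this assay only one way: diacetylamino in place of methylamino gives a number 72 percentage points lower from compound 2 to compound 3 (beyond the scatter). Diacetylamino in place of amino gives a number 5 percentage points lower from compound 1 to compound 3 (within the scatter), so the two groups cannot be told apart here, and among these three compounds the number does not follow the size of the group, with compound 2 and its methylamino group alone standing apart. Nothing available accounts for this difference between methylamino and the other two groups.

From the compounds shown here alone, whether the low number needs both acetyl groups stays open, as does whether the high number belongs to methylamino alone; a single acetylamino group, with dimethylamino or ethylamino at the same place, would separate these readings. Going by these compounds, all of these numbers come from one concentration, so they speak only of a stronger or weaker effect at that concentration, and how compound 1 and compound 3 compare at any other concentration also remains open.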